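The source may hold more compounds than are shown below. What is called first, only, known or untested is meant among the compounds shown, and "the series" means these compounds.

Measured compounds in a functional assay on HEL cells (Homo sapiens) for cytotoxicity, read by microscopy; a lower number here means that less compound is tolerated, a higher number that more compound is tolerated:

Compound 1, `CCCCCCCc1cc2cn([C@H]3C[C@H](O)[C@@H](CO)O3)c(=O)nc2o1`: > 50000 nM
Compound 2, `C=CCCCc1cc2cn([C@H]3C[C@H](O)[C@@H](CO)O3)c(=O)nc2o1`: > 200000 nM
Compound 3, `C#CCCCc1cc2cn([C@H]3C[C@H](O)[C@@H](CO)O3)c(=O)nc2o1`: > 200000 nM

Each of these three values is a limit of the assay rather than a number. Compound 3 stands at the limit of > 200000 nM in this assay, at which 2 of the 3 values shown sit. Compound 1 stands at the limit of > 50000 nM in this assay, at which 1 of the 3 values shown sits. Because all three are limits, the steps between them cannot be read: a step that the two limits leave unreadable from compound 1 to compound 2, a step that the two limits leave unreadable from compound 1 to compound 3 and a step that the two limits leave unreadable from compound 2 to compound 3 are all of unknown size.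

Compound 4, `C#CCCCCc1cc2cn([C@H]3C[C@H](O)[C@@H](CO)O3)c(=O)nc2o1`, has not yet been tested in this assay. It differs from compound 3 in one place: propargyl in place of ethynyl on a saturated chain carbon, three bonds along the chain from an aromatic carbon. Among the measured compounds shown here, no measured step is readable, so nothing in the data points to a change of any size in either direction; the three measured compounds all reached at least the lower limit, and compound 4 is expected to behave the same way. The step of a number no higher from compound 3 to compound 4 (the limit leaves the size open) is therefore expected to be nothing beyond the scatter. Compound 4 is expected to give 200000 nM, within 50000 nM to 400000 nM, most likely reported again only as a limit.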

Compound 4, minimum cytotoxic concentration: > 200000 nM
Compound 4 gave a limit, no number; the forecaster's own chance of this, stated with the estimate: 85%; the middle value sits exactly at the limit.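

In this assay compound 4 gives > 200000 nM, which is a limit of the assay and not a number. Its steps from compound 1, compound 2 and compound 3 therefore cannot be read. The compounds shown leave open at what concentration, if any, each of these four compounds becomes cytotoxic.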